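From 3-methoxyphenyl to 2-bromophenyl on an amide-type nitrogen

The source may hold more compounds than are shown below. What is called first, only, known or untested is meant among the compounds shown, and "the series" means these compounds.

- compound 1 `FC(F)(F)c1ccccc1NC(=S)N/N=C/c1ccc2ccccc2n1`: 18800 nM
- compound 2 `S=C(NCc1ccccc1)N/N=C/c1ccc2ccccc2n1`: 62800 nM
- compound 3 `COc1cccc(NC(=S)N/N=C/c2ccc3ccccc3n2)c1`: 74500 nM

In a functional assay on HeLa cells (Homo sapiens) for antiproliferative activity, read by sulforhodamine B assay, with a stated time of 72 h (on this read-out lower numbers stand for stronger inhibition and higher numbers for weaker inhibition), compound 3 gives 74500 nM and stands at the upper end of this small set. Compound 2 shares that end with 62800 nM and lies within the scatter of compound 3, while compound 1 lies clearly lower than compound 3.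

Compound 4 `S=C(N/N=C/c1ccc2ccccc2n1)Nc1ccccc1Br` has not yet been measured. It carries 2-bromophenyl in place of 3-methoxyphenyl on an amide-type nitrogen. The counted difference is 2-bromophenyl in place of 3-methoxyphenyl on an amide-type nitrogen and the rest of the structure is shared.

Going by the values given here, only one measured step bears directly on that nitrogen. It is a 1.2-fold higher number from compound 2 to compound 3 (0.07 log units; within the scatter) with 3-methoxyphenyl in place of benzyl, and it stays within the scatter. That step alone would suggest little movement. However, compound 1, with a trifluoromethyl group on its phenyl ring, gives 18800 nM and so shows a lower number with another substituted phenyl on that nitrogen. Among the compounds with values here, no measured compound carries bromine, so the expectation remains loose.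

The estimate therefore expects a 2.5-fold lower number from compound 3 to compound 4 (0.40 log units; beyond the scatter) as a moderate move toward a lower number. For compound 4 the estimated value is 30000 nM with an expected range from 9000 nM to 85000 nM in this assay until the measurement is known.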

Compound 4, half-maximal inhibitory concentration: > 100000 nM
Compound 4: no number, only a limit (the forecaster's own chance of this, stated with the estimate: 8%); middle value at least 3.3-fold (0.52 log units) away from the limit.
By their numbers in this assay, from the lowest: compound 1; then compounds 2 and 3 (each within the scatter of the next). At a limit, above all of these: compound 4.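

In this assay compound 4 gives no number, only a limit of the assay: the limit of > 100000 nM in this assay, at which 1 of the 4 values shown sits.

This result shows that a substituted phenyl on the amide-type nitrogen does not by itself bring the lower number seen with compound 1, since the exchange of substituent alone gives an at least 5.3-fold higher number from compound 1 to compound 4 (0.72 log units; beyond the scatter). With bromo in place of trifluoromethyl on an aromatic carbon, the identity of the substituent matters here, a dependence that the earlier near-equal pair could not reveal. The other two floors, an at least 1.3-fold higher number from compound 3 to compound 4 (0.12 log units; that floor lies within the scatter) and an at least 1.5-fold higher number from compound 2 to compound 4 (0.20 log units; that floor lies within the scatter), lie within the scatter, so they do not by themselves separate the 2-bromophenyl group from the 3-methoxyphenyl or benzyl groups, and only the comparison with trifluoromethyl is firm.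

The compounds shown leave open where an actual number for compound 4 would fall beyond its limit. They also leave open whether a chlorine or an amine on the phenyl ring, or a longer alkyl chain on the amide-type nitrogen, would give numbers closer to compound 1 or to compound 4.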